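The compounds below may be only part of what the source reports. "The series", "measured", "known", "first", "only" and "open" are said of these compounds alone.

Measured so far:
Compound 1 `O=C(O)CCC(=O)OCCCCCCSc1ccc([N+](=O)[O-])c2nonc12` gives 160 nM in an assay on isolated protein for inhibition of glutathione S-transferase Mu 2 (Homo sapiens), with a stated time of 10 min; a higher number here means a weaker inhibitor, a lower number a stronger inhibitor.
Compound 2 `COc1ccc(NC(=O)CCC(=O)OCCCCCCSc2ccc([N+](=O)[O-])c3nonc23)cc1OC` gives 360 nM in this assay.

Compound 2 stands highest of the two numbers in this assay; the nearest is compound 1, whose step a 2.3-fold higher number from compound 1 to compound 2 (0.35 log units; beyond the scatter) is the only one measured. Compound 3 `O=C(CCC(=O)OCCCCCCSc1ccc([N+](=O)[O-])c2nonc12)NCCN1CCCC1` carries 2-(pyrrolidin-1-yl)ethyl in place of 3,4-dimethoxyphenyl on an amide-type nitrogen. Among the measured compounds shown here, no measured step touches this change: the one known step swapped hydroxy for an arylamine, not one amide substituent for another, so it bears only loosely here. The expected step is a 1.1-fold higher number from compound 2 to compound 3 (0.05 log units; within the scatter), no larger than the scatter. Compound 3 is therefore estimated at 400 nM, within 150 nM to 1100 nM.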

Compound 3, half-maximal inhibitory concentration: 200 nM
The estimate for compound 3 lay 2.0-fold (0.30 log units) above the measured number; the range from low to high includes it.
By their numbers in this assay, from the lowest: compounds 1, 3 and 2 (each within the scatter of the next, the first and the last beyond it).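

On the amide-type nitrogen, 2-(pyrrolidin-1-yl)ethyl in place of 3,4-dimethoxyphenyl gives a 1.8-fold lower number from compound 2 to compound 3 (0.26 log units; within the scatter) in this assay and so does not separate these two amides. With (2-(pyrrolidin-1-yl)ethyl)amino in place of hydroxy on the carbonyl carbon, the result is a 1.3-fold higher number from compound 1 to compound 3 (0.10 log units; within the scatter) and, unlike the (3,4-dimethoxyphenyl)amino amide, this amide stays within the scatter of the carboxylic acid. Nothing available explains either result. The compounds shown leave open whether a morpholine in place of the pyrrolidine ring, or a longer chain to that ring, would also stay within the scatter.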